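The source may report more compounds than this note shows. Statements on the series, on what has been measured and on what is new or still open speak of the compounds shown alone.

Of the compounds shown here, three built on closely related cores have been tested in a functional assay on SMMC-7721 cells (Homo sapiens) for cytotoxicity, read by MTT assay, with a stated time of 24 h; on this read-out higher numbers stand for weaker inhibition and lower numbers for stronger inhibition. Compound 1 `N#Cc1ccc(S(=O)(=O)N2C/C(=C\c3ccncc3)C(=O)/C(=C/c3ccccc3F)C2)cc1` carries a cyano group, and in this assay compound 1 gives 16200 nM. Compound 2 `CC(=O)Nc1ccc(S(=O)(=O)N2C/C(=C\c3ccncc3)C(=O)/C(=C/c3ccccc3F)C2)cc1` differs from it in one place, (acetamido in place of cyano on an aromatic carbon), and in this assay compound 2 gives 13400 nM. The resulting step, a 1.2-fold lower number from compound 1 to compound 2 (0.08 log units; within the scatter), is small. Compound 3 `N#Cc1ccc(S(=O)(=O)N2C/C(=C\c3cccnc3)C(=O)/C(=C/c3ccccc3C(F)(F)F)C2)cc1` rests on a different core; the difference between the two cores is not broken down here. In this assay compound 3 gives 9650 nM, and its gaps to compound 2 and to compound 1 both lie within the scatter, so none of the three can be called stronger or weaker than another.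

Compound 4 `CC(=O)Nc1ccc(S(=O)(=O)N2C/C(=C\c3cccnc3)C(=O)/C(=C/c3ccccc3C(F)(F)F)C2)cc1` has not yet been measured. It differs from compound 3 by acetamido in place of cyano on an aromatic carbon, the same change, at the same place, that turns compound 1 into compound 2. Because that change gave only a 1.2-fold lower number from compound 1 to compound 2 (0.08 log units; within the scatter), a similarly small step is expected here, a 1.2-fold lower number from compound 3 to compound 4 (0.08 log units; within the scatter). On this basis compound 4 is expected to give about 8000 nM in this assay, most likely between 4000 nM and 16000 nM.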

Compound 4, half-maximal inhibitory concentration: 9830 nM
Estimate against measurement, compound 4: 1.2-fold (0.09 log units) below; measured number inside the range.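

Putting acetamido in place of cyano on the core of compound 3 gives a 1.0-fold higher number from compound 3 to compound 4 (0.01 log units; within the scatter), so in this assay this swap has no readable effect on this core. The same holds on the core of compound 1, and the two steps agree: the same change on two cores in this assay, a 1.2-fold lower number (0.08 log units; within the scatter) from compound 1 to compound 2 and a 1.0-fold higher number (0.01 log units; within the scatter) from compound 3 to compound 4, 1.2-fold (0.09 log units) apart, within the scatter of two such steps. This shows that, between these two cores, the swap carries over as a change too small to read; it does not show that the same would hold on any other core, and steps this small say nothing about why the swap has so little effect.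

The compounds shown leave open whether another group in the same place, such as an amine, a carboxylic acid or a longer chain, would give a step beyond the scatter. Among these compounds, they also leave open what each difference between the two cores contributes on its own, as no pair here isolates any one of those differences.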